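The source may report more compounds than this note shows. Statements on the series, on what has been measured and on what is new or still open speak of the compounds shown alone.

Measured so far in a functional assay on HT-1080 cells (Homo sapiens) for inhibition, read by sulforhodamine B assay, with a stated time of 48 h; on this read-out lower numbers stand for stronger inhibition and higher numbers for weaker inhibition:

Compound 1 `CCNC(=O)Nc1ccc(/C=C\c2cc(OC)c(OC)c(OC)c2)cc1` gives 29000 nM.
Compound 2 `CCNC(=O)Nc1ccc(/C=C/c2cccc(Cl)c2)cc1` gives only the assay limit > 20000 nM.
Compound 3 `CCNC(=O)Nc1ccc(/C=C/c2cc(C)cc(C)c2)cc1` likewise gives only the assay limit > 20000 nM.

Compound 2 stands at the assay limit and carries no number of its own. It shares this position with compound 3, as the limit of > 20000 nM in this assay, at which 2 of the 3 values shown sit, shows; compound 1 is the single entry with a numerical value, and that value itself is weak. For the measured compounds named here, no two of the measured compounds differ in only one place, so no measured step is available to anchor the change that follows.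

Compound 4 `O=C1NCCN1c1ccc(/C=C/c2cccc(Cl)c2)cc1` has not yet been measured. It differs from compound 2 by 2-oxoimidazolidin-1-yl in place of (ethylcarbamoyl)amino on an aromatic carbon. Going by the values given here, with compound 2 sitting at the limit and no measured step to lean on, the change from compound 2 to compound 4 is expected to give a step that the limit leaves unreadable from compound 2 to compound 4 in this assay, that is, nothing that clearly moves beyond the scatter, and the likeliest outcome is that compound 4 again returns only a limit. Compound 4 is therefore estimated at 25000 nM, within a range of 8000 nM to 80000 nM.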

Compound 4, half-maximal inhibitory concentration: > 20000 nM
Compound 4 gave a limit, no number (the forecaster's own chance of this, stated with the estimate: 60%); the middle value lies beyond the limit too.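

In this assay compound 4 gives > 20000 nM, a limit and not a number. Compound 2 also stands at a limit, so no step between compound 2 and compound 4 can be read: the limit of > 20000 nM in this assay, at which 3 of the 4 values shown sit.

Going by these compounds, whether 2-oxoimidazolidin-1-yl in place of (ethylcarbamoyl)amino changes inhibition at all remains open.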